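The source may report more compounds than this note shows. Statements on the series, on what has been measured and on what is new or still open speak of the compounds shown alone.

Among the measured compounds shown here, in a functional assay on M21 cells (Homo sapiens) for antiproliferative activity, read by sulforhodamine B assay, with a stated time of 48 h (a lower number here means a stronger inhibitor, a higher number a weaker inhibitor), compound 1 `CN1CCN(c2ccc(S(=O)(=O)Oc3cccc(F)c3)cc2)C1=O` gives 5800 nM, the higher of the two numbers recorded; compound 2 `CN1CCN(c2ccc(S(=O)(=O)Oc3cccc(I)c3)cc2)C1=O` gives 400 nM, and the step of a 15-fold lower number from compound 1 to compound 2 (1.16 log units; beyond the scatter) is the only measured step. Compound 3 `CCCN1CCN(c2ccc(S(=O)(=O)Oc3cccc(F)c3)cc2)C1=O` differs from compound 1 by ethyl in place of hydrogen on a saturated chain carbon bound to an amide-type nitrogen in a ring. For the measured compounds named here, no measured step touches that saturated chain carbon, so nothing here speaks for or against the change, and the step from compound 1 is expected to be no change at the digits printed from compound 1 to compound 3 (within the scatter), within the scatter. For compound 3 the estimated value is 5800 nM, with a range of 2000 nM to 17000 nM.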

Compound 3, half-maximal inhibitory concentration: 12000 nM
Compound 3: the middle estimate sits 2.1-fold (0.32 log units) below what was measured; low and high end bracket the measured number.
By their numbers in this assay, from the lowest: compound 2; then compound 1; then compound 3.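

Among the compounds shown here, compound 3 gives the first reading at the saturated chain carbon bound to an amide-type nitrogen in a ring: in this assay, going from methyl to propyl there brings a 2.1-fold higher number from compound 1 to compound 3 (0.32 log units; beyond the scatter). The position therefore responds to this change, in the weaker direction, though by less than a 15-fold lower number from compound 1 to compound 2 (1.16 log units; beyond the scatter) on the aromatic carbon. No measured evidence here accounts for the rise. Going by these compounds, whether a longer chain, or an amine or carboxylic acid on this chain, would go further remains open, as does how propyl behaves alongside the iodo group of compound 2.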